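Swapping a Bromine for a Fluorine on the Phenol Ring

This account rests on a few compounds, and the source may have more. Where it says the series, first, only, none or still open, it means among the compounds named here.

Of the compounds shown here, three sharing one core have been tested in an assay on isolated protein for inhibition of Amine oxidase [flavin-containing] B (Homo sapiens), read by fluorescence and Amplex Red, with stated times of 15 min and 20 min; on this read-out higher numbers stand for weaker inhibition and lower numbers for stronger inhibition. Compound 1 `COc1ccc(O)c(/C=N/c2ccc(OCc3ccccc3)cc2)c1` gives 10700 nM. Compound 2 `Oc1ccccc1/C=N/c1ccc(OCc2ccccc2)cc1` gives 25100 nM. Compound 3 `Oc1ccc(Br)cc1/C=N/c1ccc(OCc2ccccc2)cc1` gives 31700 nM, the highest of the three numbers. Its gap to compound 2 is small, a 1.3-fold higher number from compound 2 to compound 3 (0.10 log units; within the scatter), so the two cannot be ranked. Its gap to compound 1 is larger, a 3.0-fold higher number from compound 1 to compound 3 (0.47 log units; beyond the scatter), and compound 1 therefore reads as the stronger inhibitor of the pair.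

Compound 4 `Oc1ccc(F)cc1/C=N/c1ccc(OCc2ccccc2)cc1` differs from compound 3 in one place: fluoro in place of bromo on an aromatic carbon. The step that bears most directly on this is the one in which a bromo entered at the same place, a 1.3-fold higher number from compound 2 to compound 3 (0.10 log units; within the scatter), which stayed within the scatter. Replacing one halogen by another at a site where adding the halogen changed little is expected to change little again, so the step of a 1.1-fold lower number from compound 3 to compound 4 (0.05 log units; within the scatter) is estimated to lie within the scatter. Compound 4 is therefore expected to give about 28000 nM, with a likely range from 12000 nM to 65000 nM in this assay.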

Compound 4, half-maximal inhibitory concentration: 15300 nM
Compound 4: middle estimate off by 1.8-fold (0.26 log units), on the high side; low and high end bracket the measured number.
By their numbers in this assay, from the lowest: compounds 1, 4, 2 and 3 (each within the scatter of the next, the first and the last beyond it).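

At the place para to a hydroxy group, the choice of halogen can move the reading in this assay: fluoro in place of bromo gives a 2.1-fold lower number from compound 3 to compound 4 (0.32 log units; beyond the scatter), a step beyond the scatter, whereas the earlier comparison of bromo with hydrogen stayed within it. Fluoro, however, cannot be told apart from hydrogen, with a 1.6-fold lower number from compound 2 to compound 4 (0.21 log units; within the scatter), or from methoxy, with a 1.4-fold higher number from compound 1 to compound 4 (0.16 log units; within the scatter), so the bromo-to-fluoro step is the only one of the three new steps that can be read as a real difference. Nothing measured here accounts for the difference between the two halogens.

Still open, as far as these compounds go, is how chloro, an amine or a carboxylic acid would read at this same place. Also open, from the compounds shown here alone, is whether the bromo-to-fluoro step would hold up with a different group on the far side of the shared core.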